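Removing the Chain Methyl from a Nitrate Ester Dihydropyridine

The source may hold more compounds than are shown below. What is called first, only, known or untested is meant among the compounds shown, and "the series" means these compounds.

Measured so far:
- compound 1 `CC1=C(C(=O)OCCO[N+](=O)[O-])C(c2cccc3nonc23)C([N+](=O)[O-])=C(C)C1`: 3890 nM
- compound 2 `CC1=C(C(=O)O[C@@H](C)CO[N+](=O)[O-])[C@@H](c2cccc3nonc23)C([N+](=O)[O-])=C(C)C1`: 577 nM
- compound 3 `CC1=C(C(=O)O[C@H](C)CO[N+](=O)[O-])[C@@H](c2cccc3nonc23)C([N+](=O)[O-])=C(C)C1`: 59.6 nM

In a functional assay (ileum) for antagonist activity, with Cavia porcellus as the target (a lower number here means a stronger inhibitor, a higher number a weaker inhibitor), compound 3 gives the lowest of the three numbers. Its nearest neighbour is compound 2, and the step of a 9.7-fold lower number from compound 2 to compound 3 (0.99 log units; beyond the scatter) rests on the fact that compounds 2 and 3 differ only in the configuration as drawn alone. Compound 1 stands furthest away.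

Compound 4 `CC1=C(C(=O)OCCO[N+](=O)[O-])[C@@H](c2cccc3nonc23)C([N+](=O)[O-])=C(C)C1` is not yet measured. It differs from compound 3 by hydrogen in place of methyl on a saturated chain carbon bound to an oxygen next to a carbonyl group and a saturated chain carbon. Going by the values given here, the carbon that loses the methyl is the very stereocentre whose configuration separates compound 2 from compound 3, so the step of a 9.7-fold lower number from compound 2 to compound 3 (0.99 log units; beyond the scatter) is the one measurement that bears on this change; once the methyl is gone, that stereocentre no longer exists. The number for compound 1, which also carries the unbranched chain, is high. Compound 4 is therefore expected to lose part of the advantage of compound 3, with an estimated step of a 25-fold higher number from compound 3 to compound 4 (1.40 log units; beyond the scatter) towards weaker inhibition. Compound 4 is estimated at 1500 nM, within 400 nM to 5000 nM.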

Compound 4, half-maximal inhibitory concentration: 115 nM
Compound 4: the middle estimate sits 13-fold (1.12 log units) above what was measured; the measured number lies below the stated range.
By their numbers in this assay, from the lowest: compounds 3 and 4 (each within the scatter of the next); then compound 2; then compound 1.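

In this assay, there is a 1.9-fold higher number from compound 3 to compound 4 (0.29 log units; within the scatter), so at this carbon hydrogen and the methyl drawn R in compound 3 cannot be told apart. The methyl drawn S in compound 2 reads differently, with a 5.0-fold lower number from compound 2 to compound 4 (0.70 log units; beyond the scatter), so among these compounds the higher number goes with that one configuration of the methyl, not with a methyl as such. Going by these compounds alone, the unbranched chain does not by itself give a high number, as there is also a 34-fold lower number from compound 1 to compound 4 (1.53 log units; beyond the scatter), and the only difference in that pair lies at the ring carbon: the fact that one of compounds 1 and 4 is drawn with a defined configuration and the other without, at the place where they differ.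

From the compounds shown here alone, it remains open how an ethyl group or a hydroxyl group on this chain carbon would read in either configuration. Going by these compounds, the shared core drawn with the opposite configuration at the ring carbon also remains open.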